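This account rests on a few compounds, and the source may have more. Where it says the series, first, only, none or still open, it means among the compounds named here.

Series with the shared core of compound 1 `O=C(NCc1cn(Cc2ccc(F)cc2)nn1)c1cn(-c2ccccc2)nc1-c1ccccc1`, varied on the benzyl ring. In a functional assay on MCF7 cells (Homo sapiens) for antiproliferative activity, read by sulforhodamine B assay, with a stated time of 48 h (on this read-out lower numbers stand for stronger inhibition of growth and higher numbers for weaker inhibition of growth), compound 1 gives 7000 nM. Compound 2 `O=C(NCc1cn(Cc2ccc(Cl)cc2)nn1)c1cn(-c2ccccc2)nc1-c1ccccc1` carries chloro; in this assay compound 2 reaches only the limit > 100000 nM, which is the limit of > 100000 nM in this assay, at which 1 of the 3 values shown sits. Compound 3 `O=C(NCc1cn(Cc2ccc(C(F)(F)F)cc2)nn1)c1cn(-c2ccccc2)nc1-c1ccccc1` carries trifluoromethyl and in this assay gives 840 nM, the lowest number among the values shown. The measured steps read an at least 14-fold higher number from compound 1 to compound 2 (1.15 log units; beyond the scatter), an 8.3-fold lower number from compound 1 to compound 3 (0.92 log units; beyond the scatter) and an at least 110-fold lower number from compound 2 to compound 3 (2.07 log units; beyond the scatter). Compound 4 `COc1ccc(Cn2cc(CNC(=O)c3cn(-c4ccccc4)nc3-c3ccccc3)nn2)cc1` differs from compound 3 by methoxy in place of trifluoromethyl on an aromatic carbon. Among the compounds with values here, no measured step exchanges trifluoromethyl for methoxy on that aromatic carbon; the three measured steps show that exchanges there move this assay by large amounts in either direction, with the trifluoromethyl of compound 3 at the lowest number. A step towards a higher number, beyond the scatter, is therefore expected, of size a 7.1-fold higher number from compound 3 to compound 4 (0.85 log units; beyond the scatter). For compound 4 the estimate in this assay is 6000 nM, with a range from 900 nM to 60000 nM.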

Compound 4, concentration for 50% growth inhibition: > 100000 nM
Compound 4: only a limit was reported; the forecaster's own chance of this, stated with the estimate: 20%; at least 16-fold (1.22 log units) between middle value and limit.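

In this assay, methoxy in place of trifluoromethyl gives an at least 110-fold higher number from compound 3 to compound 4 (2.07 log units; beyond the scatter), and methoxy in place of fluoro gives an at least 14-fold higher number from compound 1 to compound 4 (1.15 log units; beyond the scatter), so the size of both steps is bounded from one side only. On this aromatic carbon, readable numbers now remain only with fluoro and trifluoromethyl among the four groups shown, and the step between chloro and methoxy cannot be read. Compound 4 gives a limit and not a number, the same limit as compound 2: the limit of > 100000 nM in this assay, at which 2 of the 4 values shown sit.

On these data alone, how far activity lies from the limit with chloro or methoxy stays open, and the four groups give no single trend to extend. Also open, as far as these compounds go, is whether an amine, a carboxylic acid or a nitrile on this aromatic carbon would give a readable number.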